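Chain extension on the acrylamide of a pyrimidine series

The source may report more compounds than this note shows. Statements on the series, on what has been measured and on what is new or still open speak of the compounds shown alone.

Compound 3 `COc1cc(N(C)CCN(C)C)c(NC(=O)C=C(C)C)cc1Nc1nccc(-c2cn(C)c3ccccc23)n1` carries a 2-methylprop-1-en-1-yl group on the carbonyl carbon and in a functional assay on NCI-H1975 cells (Homo sapiens) for antiproliferative activity, read by MTT assay, with a stated time of 72 h (on this read-out lower numbers stand for stronger inhibition and higher numbers for weaker inhibition), gives 5610 nM. It is the higher of the two numbers in hand, since compound 1 `C=C(Cl)C(=O)Nc1cc(Nc2nccc(-c3cn(C)c4ccccc34)n2)c(OC)cc1N(C)CCN(C)C` gives 1290 nM, with a 4.3-fold higher number from compound 1 to compound 3 (0.64 log units; beyond the scatter). Compound 2 `COc1cc(N(C)CCN(C)C)c(NC(=O)C(Cl)=C(Cl)Cl)cc1Nc1nccc(-c2cn(C)c3ccccc23)n1` gives only a limit, > 50000 nM. Against that limit an at least 8.9-fold lower number from compound 2 to compound 3 (0.95 log units; beyond the scatter). Compound 4 `CCC/C=C\C(=O)Nc1cc(Nc2nccc(-c3cn(C)c4ccccc34)n2)c(OC)cc1N(C)CCN(C)C` differs from compound 3 by pent-1-en-1-yl in place of 2-methylprop-1-en-1-yl on a carbonyl carbon. For the measured compounds named here, no measured step changes this part of the molecule in the same way; the measured steps show only that the group on the carbonyl carbon moves this assay modestly or strongly. Compound 4 is therefore expected to stay close to compound 3, with a 1.4-fold lower number from compound 3 to compound 4 (0.15 log units; within the scatter) within the scatter. Compound 4 is estimated at 4000 nM, between 1500 nM and 12000 nM.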

Compound 4, half-maximal inhibitory concentration: 1220 nM
Compound 4: middle estimate off by 3.3-fold (0.52 log units), on the high side; the whole stated range lies above it.
By their numbers in this assay, from the lowest: compounds 4 and 1 (each within the scatter of the next); then compound 3. At a limit, above all of these: compound 2.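

A chlorine-free group on the carbonyl carbon can match the 1-chloroethenyl group in this assay, with a 1.1-fold lower number from compound 1 to compound 4 (0.02 log units; within the scatter). Among the groups without chlorine the outcome still depends on the group, since pent-1-en-1-yl in place of 2-methylprop-1-en-1-yl gives a 4.6-fold lower number from compound 3 to compound 4 (0.66 log units; beyond the scatter). The step from the 1,2,2-trichloroethenyl group, an at least 40-fold lower number from compound 2 to compound 4 (1.61 log units; beyond the scatter), rests on a limit and not a number: the limit of > 50000 nM in this assay, at which 1 of the 4 values shown sits.

The compounds shown leave open how a longer chain than pent-1-en-1-yl would read in this assay. They also leave open what an amine on that chain would do.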